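Amide substituent change at the pyrrole carboxamide end

A few compounds are considered here, and "the series" means these few. Any claim that something is new, unique, unknown or untested is made for them only; others in the source may bear on it.

Measured so far:
- compound 1 `CCN(CC)CCCNC(=O)c1ccc(C(CC)(CC)c2ccc(OCC(=O)C(C)(C)C)c(C)c2)n1CC` gives 22 nM
- compound 2 `CCN(CC)CCCNC(=O)c1ccc(C(CC)(CC)c2ccc(OCC(O)C(C)(C)C)c(C)c2)n1CC` gives 66 nM

Among the compounds with values here, in an assay on HL-60 cells for agonist activity at vitamin D3 receptor (Homo sapiens), read by microscopy, with a stated time of 96 h (a higher number here means that more compound is needed for the effect, a lower number that less compound is needed), compound 2 stands highest of the two numbers measured; its nearest neighbour is compound 1, which differs only at the chain on the aromatic oxygen, and the step of a 3.0-fold higher number from compound 1 to compound 2 (0.48 log units; beyond the scatter) is the only step measured.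

Compound 3 `CCn1c(C(=O)N(C)c2ccccc2)ccc1C(CC)(CC)c1ccc(OCC(O)C(C)(C)C)c(C)c1` has not yet been measured. It differs from compound 2 on the carbonyl carbon: methyl(phenyl)amino in place of (3-(diethylamino)propyl)amino on a carbonyl carbon. Within the data shown here, the one measured step concerns the other end of the shared core, the ketone against the secondary alcohol on the chain bound to the aromatic oxygen, and tells nothing about the amide substituent. Among the measured compounds shown here, no measured step bears on the change from compound 2 to compound 3, so there is no ground in these data for a step in either direction beyond the scatter, and a wide range has to be allowed.

On that footing compound 3 is estimated at 70 nM, with a range from 15 nM to 350 nM in this assay, which means an expected step of a 1.1-fold higher number from compound 2 to compound 3 (0.03 log units; within the scatter).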

Compound 3, half-maximal effective concentration: 6400 nM
Compound 3: middle estimate off by 91-fold (1.96 log units), on the low side; measured number above the stated range.
By their numbers in this assay, from the lowest: compound 1; then compound 2; then compound 3.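

In this assay, the substituent on the carbonyl carbon proves a far more sensitive point of the series than the chain on the aromatic oxygen: the replacement of (3-(diethylamino)propyl)amino by methyl(phenyl)amino gives a 97-fold higher number from compound 2 to compound 3 (1.99 log units; beyond the scatter) and so outweighs a 3.0-fold higher number from compound 1 to compound 2 (0.48 log units; beyond the scatter) by a wide margin. The change is not a single one, since a chain with no ring, 1 hydrogen-bond donor and 1 hydrogen-bond acceptor leaves, while a group with one six-membered aromatic ring and neither donor nor acceptor enters, and this one step cannot separate those differences. Nothing on hand accounts for the size of this step.

The compounds shown leave open which of these differences carries the step: a plain phenylamino group would restore the amide hydrogen without the diethylamino group, while a methyl on the amide nitrogen with the 3-(diethylamino)propyl chain kept would test the opposite case. Also open, from the compounds shown here alone, are a shorter chain ending in a primary amine or a carboxylic acid at this place, and whether the same amide change on the ketone of compound 1 gives a step of similar size.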